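The compounds below may be only part of what the source reports. "The series", "measured", "known", "first", "only" and "open" are said of these compounds alone.

Measured so far in an assay on MDA-MB-231 cells for displacement of a labelled ligand from C-X-C chemokine receptor type 4 (Homo sapiens), read by fluorescence and microscopy, with stated times of 10 min and 30 min; a higher number here means that more compound is needed for the effect, a lower number that less compound is needed:
- compound 1 `COc1ccccc1C(=O)NCc1ccc(CNS(=O)(=O)c2cccc(C)c2)cc1`: 1000 nM
- compound 2 `COc1ccccc1C(=O)NCc1ccc(CNS(=O)(=O)c2ccc(F)cc2)cc1`: 100 nM
- compound 3 `COc1ccccc1C(=O)NCc1ccc(CNS(=O)(=O)c2ccccc2C)cc1`: 1000 nM

Compound 3 stands level with compound 1 at the digits printed, the two together giving the highest numbers of the three; compound 2 lies furthest from it, with a 10-fold higher number from compound 2 to compound 3 (1.00 log units; beyond the scatter) marking the gap.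

The next compound is compound 4 `COc1ccccc1C(=O)NCc1ccc(CNS(=O)(=O)c2ccc([N+](=O)[O-])cc2)cc1`. Relative to compound 3 the change is 4-nitrophenyl in place of 2-methylphenyl on a sulfonyl sulfur. Within the data shown here, no measured step involves a 4-nitrophenyl, so the only guidance comes from steps in which the group on the sulfonyl sulfur was exchanged: a 10-fold lower number from compound 1 to compound 2 (1.00 log units; beyond the scatter) and a 10-fold higher number from compound 2 to compound 3 (1.00 log units; beyond the scatter), both beyond the scatter, both favouring the 4-fluorophenyl over either methylphenyl. Whether a 4-nitrophenyl follows the 4-fluorophenyl or the methylphenyls cannot be read from these data, so a lower number than compound 3 is expected, but with a wide range.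

The estimate for compound 4 in this assay is 300 nM, between 80 nM and 1500 nM, corresponding to an expected step of a 3.3-fold lower number from compound 3 to compound 4 (0.52 log units; beyond the scatter).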

Compound 4, effective concentration (reported as EC, without a stated level of effect): 100 nM
Estimate against measurement, compound 4: 3.0-fold (0.48 log units) above; low and high end bracket the measured number.
By their numbers in this assay, from the lowest: compounds 2 and 4 (each within the scatter of the next); then compounds 1 and 3 (each within the scatter of the next).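

In this assay, nitro in place of fluoro on an aromatic carbon leaves the number unmoved (no change at the digits printed from compound 2 to compound 4 (within the scatter)), so the low level of compound 2 is no longer tied to the 4-fluorophenyl alone. The 4-nitrophenyl also stands apart from both methylphenyl groups (a 10-fold lower number from compound 3 to compound 4 (1.00 log units; beyond the scatter)) and (a 10-fold lower number from compound 1 to compound 4 (1.00 log units; beyond the scatter)), which divides the four compounds into two pairs: compound 2 with compound 4, and compound 1 with compound 3. No supporting data bear on why the compounds divide in this way.

A 4-methylphenyl on the sulfonyl sulfur would show whether the division follows the kind of group or where it sits on the ring, and these compounds cannot separate the two. Going by these compounds, it also remains open whether an unsubstituted phenyl, a 4-aminophenyl or a 4-carboxyphenyl would fall with compound 2 and compound 4.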